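The source may hold more compounds than are shown below. What is called first, only, known or untested is meant among the compounds shown, and "the series" means these compounds.

Three ureas sharing one core have been run through an ADME assay for permeability, using PAMPA, at pH 7.4; a lower number here means that the compound crosses the layer more slowly, a higher number that the compound crosses the layer faster. Compound 1 `Cc1cc(NC(=O)Nc2ccccc2OC(F)(F)F)c2ccccc2n1` gives 1110 10^-6 cm/s. Compound 2 `CSc1ccc(NC(=O)Nc2cc(C)nc3ccccc23)cc1` gives 473 10^-6 cm/s. Compound 3 `COC(=O)c1cccc(NC(=O)Nc2cc(C)nc3ccccc23)c1` gives 746 10^-6 cm/s. Of these three numbers, compound 2 stands lowest. Compound 3 is its nearest neighbour, and the gap between the two falls within the usual scatter of such measurements, so the two cannot be ordered. Compound 1 lies furthest away, and that gap is beyond the scatter, so compound 1 does cross the layer faster than compound 2.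

The account now turns to compound 4 `Cc1cc(NC(=O)Nc2ccc(Cl)cc2)c2ccccc2n1`, which has not yet been measured in this assay. It differs from compound 2 in a single place: chloro in place of methylsulfanyl on an aromatic carbon. The methylsulfanyl group leaves and a chloro group enters, on an aromatic carbon of a six-membered aromatic ring of carbon only, para to a large group. Within the data shown here, no pair of measured compounds differing in one place is available, so the size of the step must be judged from the three numbers alone. The step is expected to be a 1.3-fold higher number from compound 2 to compound 4 (0.10 log units; within the scatter), upward if anything and not beyond the scatter. Compound 4 is accordingly estimated at 600 10^-6 cm/s, within a range from 350 10^-6 cm/s to 1000 10^-6 cm/s.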

Compound 4, apparent permeability: 537 10^-6 cm/s
Compound 4: middle estimate off by 1.1-fold (0.05 log units), on the high side, and the stated range covers the measured number.
By their numbers in this assay, from the lowest: compounds 2, 4, 3 and 1 (each within the scatter of the next, the first and the last beyond it).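

In this assay, among these compounds, chloro in place of methylsulfanyl on an aromatic carbon of the six-membered ring, para to a large group, gives a 1.1-fold higher number from compound 2 to compound 4 (0.06 log units; within the scatter), the first step that can be read for a change in one place. The earlier compounds shown here offered no such pair, whereas this one shows that the exchange, in which a group of two heavy atoms with one hydrogen-bond acceptor gives way to a single chlorine with none, does not separate compound 4 from compound 2 in this read-out. No measured property is available that would account for this outcome.

On these data alone, with a single pair at this position, it remains open whether an amine, a carboxylic acid or a longer chain on the same aromatic carbon would give a step beyond the scatter. As far as these compounds go, it is equally open whether chloro in place of methylsulfanyl would give a step of similar size on another carbon of that ring.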